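A few compounds are considered here, and "the series" means these few. Any claim that something is new, unique, unknown or untested is made for them only; others in the source may bear on it.

Working notes on the series. Three compounds have numbers in a functional assay on SK-OV-3 cells (Homo sapiens) for cytotoxicity, read by MTT assay, with a stated time of 48 h; on this read-out higher numbers stand for weaker inhibition and lower numbers for stronger inhibition. Compound 1 `CCCCOc1ccc2c(Cl)ccnc2c1` gives 4130 nM. Compound 2 `C=CCOc1ccc2c(NCCN(C)C)ccnc2c1` gives 1560 nM. Going by the values given here, compound 3 `C=CCOc1ccc2c(NCCCN(C)C)ccnc2c1` gives 4250 nM, the highest of the three numbers; its gap to compound 1 lies within the scatter, while compound 2 is separated from it by the step of a 2.7-fold higher number from compound 2 to compound 3 (0.44 log units; beyond the scatter), the one measured step in this set.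

Compound 4 `C=CCOc1ccc2c(Cl)ccnc2c1` has not been measured. It differs from compound 3 by chloro in place of (3-(dimethylamino)propyl)amino on an aromatic carbon. Among the compounds with values here, no measured step covers this kind of exchange: the one step on record, from compound 2 to compound 3, changes only the chain length of the amine substituent and says nothing about dropping the amine altogether. What does bear on it is compound 1, which carries the same chloro substituent on the same core, with a butoxy group where compound 4 has an allyloxy group, and which sits in this assay at a number indistinguishable from that of compound 3. The expectation for compound 4 is therefore a step of a 1.1-fold lower number from compound 3 to compound 4 (0.03 log units; within the scatter), no real change beyond the scatter. Compound 4 is estimated at 4000 nM, with a range of 1500 nM to 11000 nM.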

Compound 4, half-maximal inhibitory concentration: 4030 nM
Estimate against measurement, compound 4: 1.0-fold (0.00 log units) below; measured number inside the range.
By their numbers in this assay, from the lowest: compound 2; then compounds 4, 1 and 3 (each within the scatter of the next).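

At this aromatic carbon, opposite the ring nitrogen, chloro in place of (3-(dimethylamino)propyl)amino leaves the number in this assay unchanged within the scatter (a 1.1-fold lower number from compound 3 to compound 4 (0.02 log units; within the scatter)), whereas chloro in place of (2-(dimethylamino)ethyl)amino gives a modest rise beyond it (a 2.6-fold higher number from compound 2 to compound 4 (0.41 log units; beyond the scatter)); among the allyloxy compounds, an amine side chain at this place therefore separates from chloro only in its (2-(dimethylamino)ethyl)amino form. With chloro held at this carbon, vinyl in place of propyl on the ether chain shows no change beyond the scatter (a 1.0-fold lower number from compound 1 to compound 4 (0.01 log units; within the scatter)), so butoxy and allyloxy are not told apart on this background. No measurement at hand accounts for the difference between the two amine side chains.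

Going by these compounds, whether the lower number of compound 2 carries over to a morpholine or a diethylamino group at the end of the ethyl chain remains open. Also open, on these data alone, is what butoxy in place of allyloxy does when (2-(dimethylamino)ethyl)amino, rather than chloro, occupies the aromatic carbon.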